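Swapping the aryl group on a fatty acid receptor agonist

The compounds below may be only part of what the source reports. "The series", "measured", "known", "first", "only" and "open" are said of these compounds alone.

Compound 1 `CC#CC(CC(=O)O)c1ccc(OCc2ccc3nc(-c4ccc(OC)cc4)cn3c2)cc1`: 47 nM
Compound 2 `CC#CC(CC(=O)O)c1ccc(OCc2ccn3cc(-c4ccc(CC)cc4)nc3c2)cc1`: 671 nM

Of the compounds shown here, two have been tested so far in an assay on isolated protein for agonist activity at Free fatty acid receptor 1 (Homo sapiens); on this read-out lower numbers stand for an effect already at smaller amounts and higher numbers for an effect only at larger amounts of compound. Compound 1 gives 47 nM, and compound 2 gives 671 nM, the higher of the two numbers, so compound 2 needs more material than compound 1 to reach the same effect. The two differ in several places at once, so no single structural change can be tied to that gap.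

Compound 3 `CC#CC(CC(=O)O)c1ccc(OCc2ccn3cc(-c4ccccc4F)nc3c2)cc1` keeps the core of compound 2 and alters only the attached aryl group: 2-fluorophenyl in place of 4-ethylphenyl on an aromatic carbon. Among the compounds with values here, with only two measured compounds, and none of them differing by exactly this kind of change, there is no step to lean on. The expected step of a 1.1-fold lower number from compound 2 to compound 3 (0.05 log units; within the scatter) is therefore small, not clearly beyond the scatter in either direction. Compound 3 is estimated at 600 nM, with a likely range from 200 nM to 2000 nM.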

Compound 3, half-maximal effective concentration: 705 nM
For compound 3 the middle estimate is 1.2-fold (0.07 log units) below the measured one; the measured number falls inside the stated range.
By their numbers in this assay, from the lowest: compound 1; then compounds 2 and 3 (each within the scatter of the next).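

In this assay, putting 2-fluorophenyl in place of 4-ethylphenyl on this aromatic carbon gives a 1.1-fold higher number from compound 2 to compound 3 (0.02 log units; within the scatter) and so leaves the two compounds indistinguishable. Within the data shown here, this is the first comparison here that changes only one place, and it shows that two aryl groups, differing in their substituent and in where it sits on the ring, can occupy this carbon with no measurable difference on this read-out. Nothing available explains why the two groups give such similar numbers.

As far as these compounds go, it remains open whether an aryl group carrying an amine or a carboxylic acid would also match these two compounds at this carbon. Compound 1 differs from compound 2 and compound 3 in more than one place, so which structural feature goes with its lower number also remains unresolved.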